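Bromo in place of hydrogen: cytotoxicity notes

The source may report more compounds than this note shows. Statements on the series, on what has been measured and on what is new or still open speak of the compounds shown alone.

In an ADME assay on Vero cells (Chlorocebus sabaeus) for cytotoxicity, read by crystal violet staining (on this read-out higher numbers stand for lower toxicity in this test and lower numbers for higher toxicity in this test), compound 3 `c1ccc(/N=N/N2CCCC2)cc1` stands at > 100000 nM, which is a limit and not a number. Compound 1 `COc1ccc(/N=N/N2CCCC2)cc1` gives 90000 nM in this assay. Compound 2 `O=[N+]([O-])c1ccc(/N=N/N2CCCC2)cc1` gives 90000 nM there, and no change at the digits printed from compound 1 to compound 2 (within the scatter).

The change to compound 4 `Brc1ccc(/N=N/N2CCCC2)cc1` is bromo in place of hydrogen on an aromatic carbon, with bromo in place of hydrogen on an aromatic carbon. The measured exchanges on an aromatic carbon bear on it: an at least 1.1-fold higher number from compound 1 to compound 3 (0.04 log units; that floor lies within the scatter) and an at least 1.1-fold higher number from compound 2 to compound 3 (0.04 log units; that floor lies within the scatter), both with floors within the scatter. No step beyond the scatter is therefore expected in this assay, and no direction is favoured. The expected step is an at least 1.1-fold lower number from compound 3 to compound 4 (0.07 log units; that floor lies within the scatter). For compound 4 the estimate is 85000 nM, with an expected range of 45000 nM to 100000 nM.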

Compound 4, half-maximal cytotoxic concentration: >= 100000 nM
Compound 4: no number, only a limit; the forecaster's own chance of this, stated with the estimate: 35%; at least 1.1-fold (0.07 log units) between middle value and limit.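

In this assay compound 4 gives only a limit and not a number: the limit of >= 100000 nM in this assay, at which 1 of the 4 values shown sits.

Compound 3 also stands at a limit, so the step between these two cannot be read. Bromo in place of nitro gives an at least 1.1-fold higher number from compound 2 to compound 4 (0.04 log units; that floor lies within the scatter), and bromo in place of methoxy gives an at least 1.1-fold higher number from compound 1 to compound 4 (0.04 log units; that floor lies within the scatter), so no step beyond the scatter is shown for bromo on this aromatic carbon.

From the compounds shown here alone, whether compound 3 and compound 4 differ at all remains open. Also open, going by these compounds, is whether an amine or a carboxylic acid on this carbon would give a measured number.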